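The compounds below may be only part of what the source reports. "The series", "measured", "known", "first", "only" and "open" are said of these compounds alone.

In an assay on cells for inhibition of Polyunsaturated fatty acid 5-lipoxygenase (Homo sapiens), read by HPLC, with stated times of 15 min and 10 min (on this read-out lower numbers stand for stronger inhibition and higher numbers for weaker inhibition), compound 1 `COc1cccc(-c2nc3ccc(C)cn3c2NC2CCCCC2)c1` gives 1220 nM, and compound 2 `Cc1ccc2nc(-c3ccccc3O)c(NC3CCCCC3)n2c1` gives 1900 nM. Among the compounds with values here, the only measured step, a 1.6-fold higher number from compound 1 to compound 2 (0.19 log units; within the scatter), does not separate the two, so compound 2 stands alongside compound 1 rather than apart from it. Within the data shown here, compound 3 `COc1ccc(-c2nc3ccc(C)cn3c2NC2CCCCC2)cc1` is the one remaining analogue: relative to compound 2 the change is 4-methoxyphenyl in place of 2-hydroxyphenyl on an aromatic carbon. Among the measured compounds shown here, the single step that bears on this, a 1.6-fold higher number from compound 1 to compound 2 (0.19 log units; within the scatter), already shows that exchanging one substituted phenyl for another on this carbon of the shared core left the number within the scatter, and the methoxyphenyl of compound 1 is closer in kind to compound 3 than the hydroxyphenyl of compound 2. Compound 3 is therefore expected to give 1500 nM, between 500 nM and 4500 nM. The expected step of a 1.3-fold lower number from compound 2 to compound 3 (0.10 log units; within the scatter) is estimated to stay within the scatter, with no clear direction.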

Compound 3, half-maximal inhibitory concentration: 1300 nM
Compound 3: the middle estimate sits 1.2-fold (0.06 log units) above what was measured; the range from low to high includes it.
By their numbers in this assay, from the lowest: compounds 1, 3 and 2 (each within the scatter of the next).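

In this assay, the step of a 1.5-fold lower number from compound 2 to compound 3 (0.16 log units; within the scatter) and the step of a 1.1-fold higher number from compound 1 to compound 3 (0.03 log units; within the scatter) both stay within the scatter, so 4-methoxyphenyl cannot be told apart from either group tested earlier on this aromatic carbon. The result adds a third substituted phenyl to the set, and it shows that neither exchanging 3-methoxyphenyl for 4-methoxyphenyl nor exchanging 2-hydroxyphenyl, with its hydrogen-bond donor, for 4-methoxyphenyl, which has none, separates the numbers on the shared core. No measurement at hand accounts for how closely these numbers sit together. The three compounds leave open whether a phenyl carrying a carboxylic acid or a dimethylamino group, or a pyridine in place of the phenyl, would give a step beyond the scatter at this carbon. They also leave open whether replacing the cyclohexylamino group with a shorter chain such as ethylamino would do so.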